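This account rests on a few compounds, and the source may have more. Where it says the series, first, only, none or still open, it means among the compounds named here.

Working notes on the group carried by the amine nitrogen of the shared core. Compound 3 `COc1ccccc1NC1=CC(=O)c2nc3n(c2C1=O)[C@H]1OC[C@@H](O)[C@H]1OC3` has a 2-methoxyphenyl group there and reads > 4000 nM in a functional assay on MCF7 cells (Homo sapiens) for inhibition, read by sulforhodamine B assay (on this read-out lower numbers stand for stronger inhibition and higher numbers for weaker inhibition), which is a limit and not a number. Compound 1 `O=C1C=C(NC2CCCCC2)C(=O)c2c1nc1n2[C@H]2OC[C@@H](O)[C@H]2OC1`, with cyclohexyl, reads > 8000 nM, also a limit. For the measured compounds named here, compound 2 `CCc1ccc(NC2=CC(=O)c3nc4n(c3C2=O)[C@H]2OC[C@@H](O)[C@H]2OC4)cc1`, with 4-ethylphenyl, gives 960 nM, the only true number so far.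

Compound 4 `O=C1C=C(Nc2ccc(C(F)(F)F)cc2)C(=O)c2c1nc1n2[C@H]2OC[C@@H](O)[C@H]2OC1` is the next to read: 4-(trifluoromethyl)phenyl in place of 2-methoxyphenyl on an amine nitrogen. In words, 4-(trifluoromethyl)phenyl replaces 2-methoxyphenyl on an amine nitrogen.

Going by the values given here, two measured steps bear on this. The change to 4-ethylphenyl gave an at least 8.3-fold lower number from compound 1 to compound 2 (0.92 log units; beyond the scatter), while moving away from that group gave an at least 4.1-fold higher number from compound 2 to compound 3 (0.61 log units; beyond the scatter). Both are beyond the scatter, but not every aryl group gains, as compound 3 goes against any such trend. Compound 2 is the closest measured neighbour, so a lower number than for compound 3 is expected, though probably not as low as for compound 2. The expected change is an at least 2.6-fold lower number from compound 3 to compound 4 (0.42 log units; beyond the scatter). The estimate for compound 4 is 1500 nM, with an expected range of 500 nM to 5000 nM.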

Compound 4, half-maximal inhibitory concentration: > 4000 nM
Compound 4: a limit, no number; the forecaster's own chance of this, stated with the estimate: 20%; middle value at least 2.6-fold (0.42 log units) from the limit.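

In this assay, trifluoromethyl in place of ethyl on an aromatic carbon gives an at least 4.1-fold higher number from compound 2 to compound 4 (0.61 log units; beyond the scatter), so the gain seen with 4-ethylphenyl does not carry over to 4-(trifluoromethyl)phenyl, and an aryl group on the amine nitrogen is not enough to reach the level of compound 2. Compound 4 reads as a limit and not a number, and it shares that limit with compound 3: the limit of > 4000 nM in this assay, at which 2 of the 4 values shown sit. The steps joining compound 4 to compound 3 and to compound 1 cannot be read, as each has a limit at both ends.

On these data alone, whether a longer chain such as propyl, or an amine, in place of ethyl on that aromatic carbon would keep the potency of compound 2 stays open. The limits also leave any ranking among compound 1, compound 3 and compound 4 open.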